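The compounds below may be only part of what the source reports. "The series", "measured", "known", "first", "only" and "open" are said of these compounds alone.

Compound 1 `Cc1nc(=O)[nH]c(-c2cccc(O)c2)c1C(=O)OCC1CCCCC1`: > 10000 nM
Compound 2 `CCC1=C(C(=O)OCC2CCCCC2)C(c2cccc(O)c2)NC(=O)N1`: > 10000 nM

Both entries were measured in an ADME assay on CEMx174 cells (Homo sapiens) for cytotoxicity (a lower number here means that less compound is tolerated, a higher number that more compound is tolerated), and neither is a number. Compound 1 gives > 10000 nM, which is a limit. Compound 2 gives > 10000 nM, which is also a limit. Compound 2 therefore stands at the limit of > 10000 nM in this assay, at which 2 of the 2 values shown sit.

The next compound is compound 3 `O=C1NC(c2ccccc2)=C(C(=O)OCC2CCCCC2)C(c2cccc(O)c2)N1`, which carries phenyl in place of ethyl on a double-bonded ring carbon, next to the ring nitrogen: phenyl in place of ethyl on a double-bonded ring carbon. Within the data shown here, no measured step is available to size this change. No shift beyond the scatter is expected in this assay, in either direction, and this expectation rests only on (the limit of > 10000 nM in this assay, at which 2 of the 2 values shown sit). The expected change is a step that the limit leaves unreadable from compound 2 to compound 3. For compound 3 the estimate is 12000 nM, with an expected range from 4000 nM to 40000 nM.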

Compound 3, half-maximal cytotoxic concentration: > 10000 nM
Compound 3: no number, only a limit; the forecaster's own chance of this, stated with the estimate: 70%; the middle value does not contradict the limit.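

In this assay compound 3 gives > 10000 nM, which is a limit. Compound 2 and compound 3 both carry only limits, so no step can be read between them. The compounds shown leave open where the actual cytotoxic concentration of each lies, and whether phenyl in place of ethyl shifts it at all.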